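One fluoro fewer on the way to compound 3

The source may hold more compounds than are shown below. What is called first, only, known or untested is meant among the compounds shown, and "the series" means these compounds.

In a physicochemical assay for lipophilicity, read by HPLC, at pH 7.4 (a lower number here means a more polar compound, a higher number a more lipophilic compound), compound 2 (`Cc1c(C(=O)Nc2ccccn2)ccc(F)c1F`) gives 2.8 and stands highest of the two numbers available. Compound 1 (`Cc1c(F)cccc1C(=O)Nc1cc(Cl)ccn1`) lies lower at 2.3 and the gap between them is beyond the usual scatter. Compound 3 (`Cc1c(F)cccc1C(=O)Nc1ccccn1`) differs from compound 2 by hydrogen in place of fluoro on an aromatic carbon. Among the compounds with values here, no measured pair shows this change on its own, so its size can only be judged. In this assay a modest downward move is expected, estimated as a number 0.40 log units lower from compound 2 to compound 3 (beyond the scatter) and not far beyond the scatter. Compound 3 is estimated at 2.4 within a range from 2 to 2.8 once measured.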

Compound 3, distribution coefficient: 2.6
The estimate for compound 3 lay 0.20 log units below the measured number, and the stated range covers the measured number.
By their numbers in this assay, from the lowest: compounds 1, 3 and 2 (each within the scatter of the next, the first and the last beyond it).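

In this assay, within the data shown here, hydrogen in place of fluoro on an aromatic carbon, ortho to a fluoro group, gives a number 0.20 log units lower from compound 2 to compound 3 (within the scatter) and is the first reading of this change on its own. Hydrogen in place of chloro on an aromatic carbon gives a number 0.30 log units higher from compound 1 to compound 3 (within the scatter) and so each of these two single changes stays within the scatter. Going by these compounds, whether a larger group at the same place, such as an amine or a carboxylic acid, would move the number beyond the scatter stays open. Nothing available explains the size of either step.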